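The source may report more compounds than this note shows. Statements on the series, on what has been measured and on what is new or still open speak of the compounds shown alone.

Compound 1 `Cc1ccc(-c2ccnc3c2c(-c2ccccc2)nn3-c2ccccc2)cc1` and compound 2 `Fc1ccc(-c2ccnc3c2c(-c2ccccc2)nn3-c2ccccc2)cc1` share one core and differ only in one place, (fluoro in place of methyl on an aromatic carbon). In a functional assay on MCF7 cells (Homo sapiens) for inhibition, read by MTT assay, with a stated time of 48 h (on this read-out lower numbers stand for stronger inhibition and higher numbers for weaker inhibition), compound 1 gives 5590 nM, while compound 2 gives 1570 nM, so that a 3.6-fold lower number from compound 1 to compound 2 (0.55 log units; beyond the scatter). Compound 3 `Cc1ccc(C(=O)C=CNc2cc(-c3ccccc3)nn2-c2ccccc2)cc1` is built on a different core; how its core differs from that of compound 1 is not broken down here. In this assay compound 3 gives 30200 nM. Compound 4 `O=C(C=CNc1cc(-c2ccccc2)nn1-c1ccccc1)c1ccc(F)cc1` is compound 3 with the same change applied, (fluoro in place of methyl on an aromatic carbon). Because the change is the same one that gave a 3.6-fold lower number from compound 1 to compound 2 (0.55 log units; beyond the scatter), a lower number for compound 4 is expected, though a somewhat smaller step is allowed for, since the core is not the same. The expected step is a 3.0-fold lower number from compound 3 to compound 4 (0.48 log units; beyond the scatter). Compound 4 is thus estimated at 10000 nM, between 4000 nM and 30000 nM.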

Compound 4, half-maximal inhibitory concentration: 9180 nM
Estimate against measurement, compound 4: 1.1-fold (0.04 log units) above; low and high end bracket the measured number.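

In this assay, putting fluoro in place of methyl gives a 3.3-fold lower number from compound 3 to compound 4 (0.52 log units; beyond the scatter), and this step matches the earlier one made on the other core: the same change on two cores in this assay, a 3.6-fold lower number (0.55 log units; beyond the scatter) from compound 1 to compound 2 and a 3.3-fold lower number (0.52 log units; beyond the scatter) from compound 3 to compound 4, 1.1-fold (0.03 log units) apart, within the scatter of two such steps

Within these two pairs, then, the change carries from one core to the other with its size kept. Within the data shown here, this rests on only two pairs, both swapping 4-methylphenyl for 4-fluorophenyl, so it does not show why the numbers fall or that the same step would appear on any further core.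

The compounds shown leave open how other groups in that place, such as chloro, methoxy or an amine, would compare with fluoro. They also leave open whether the same change behaves alike elsewhere on these molecules.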